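Amine variations on the glycinamide side chain

A few compounds are considered here, and "the series" means these few. Any claim that something is new, unique, unknown or untested is made for them only; others in the source may bear on it.

Of the compounds shown here, three of the shared core have been measured in a functional assay on PC-3 cells (Homo sapiens) for cytotoxicity, read by MTT assay, with a stated time of 48 h; a lower number here means a stronger inhibitor, a higher number a weaker inhibitor. Compound 1 `O=C(CCl)N1N=C(c2cc3ccccc3oc2=O)CC1c1ccccc1` gives 2980 nM. Compound 2 `CNCC(=O)N1N=C(c2cc3ccccc3oc2=O)CC1c1ccccc1`, with methylamino in place of chloro, gives 2300 nM, a change of a 1.3-fold lower number from compound 1 to compound 2 (0.11 log units; within the scatter). Compound 3 `CCCNCC(=O)N1N=C(c2cc3ccccc3oc2=O)CC1c1ccccc1`, with propylamino in place of chloro, gives 7270 nM. Compound 3 therefore stands highest of the three numbers, a 2.4-fold higher number from compound 1 to compound 3 (0.39 log units; beyond the scatter) and a 3.2-fold higher number from compound 2 to compound 3 (0.50 log units; beyond the scatter).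

Compound 4 `CC(C)(C)NCC(=O)N1N=C(c2cc3ccccc3oc2=O)CC1c1ccccc1` differs from compound 3 in one place: tert-butyl in place of propyl on an amine nitrogen. The step that bears most directly on this is the lengthening of the alkyl on the amine nitrogen from compound 2 to compound 3, a 3.2-fold higher number from compound 2 to compound 3 (0.50 log units; beyond the scatter), which carried a modest weakening beyond the scatter. The step of a 2.4-fold higher number from compound 1 to compound 3 (0.39 log units; beyond the scatter) points the same way. Within the data shown here, no measured pair addresses branching of the alkyl at constant or near-constant size, so the direction of this particular change is not established by the series; the only trend seen is that a larger alkyl on the amine nitrogen has so far weakened inhibition.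

For compound 4 in this assay a small further weakening or no change beyond the scatter is expected, the estimate being 9000 nM within 3500 nM to 22000 nM. The expected step is a 1.2-fold higher number from compound 3 to compound 4 (0.09 log units; within the scatter).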

Compound 4, half-maximal inhibitory concentration: 16400 nM
Estimate against measurement, compound 4: 1.8-fold (0.26 log units) below; low and high end bracket the measured number.
By their numbers in this assay, from the lowest: compounds 2 and 1 (each within the scatter of the next); then compound 3; then compound 4.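

In this assay, tert-butyl in place of propyl on an amine nitrogen gives a 2.3-fold higher number from compound 3 to compound 4 (0.35 log units; beyond the scatter) and so extends the rise in the number beyond the propyl compound, showing that this position does not level off at propyl. Among the alkylamino compounds the numbers now run in the order methyl, propyl, tert-butyl, none of the three going against that order, and the full span is a 7.1-fold higher number from compound 2 to compound 4 (0.85 log units; beyond the scatter) for tert-butyl in place of methyl. Against the chloro compound the change to (tert-butyl)amino gives a 5.5-fold higher number from compound 1 to compound 4 (0.74 log units; beyond the scatter) and is the largest departure from chloro so far, while the methylamino compound stays within the scatter of chloro; nothing on hand accounts for these shifts.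

Propyl and tert-butyl differ in both branching and size, so the compounds shown cannot say which of the two goes with the higher number. An isopropyl or an unbranched butyl on the same amine nitrogen would separate them, and a dimethylamino group would show how the number responds to a second alkyl on that nitrogen.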